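Urea to aryl amide on the shared core

This account rests on a few compounds, and the source may have more. Where it says the series, first, only, none or still open, it means among the compounds named here.

Of the compounds shown here, three built on the same core have been measured in an assay on LtK cells with ATP-sensitive inward rectifier potassium channel 11 (Homo sapiens) as the target; a higher number here means that more compound is needed for the effect, a lower number that less compound is needed. Compound 1 `CCC(=O)Nc1c(C(O)(C(F)(F)F)C(F)(F)F)ccc2ccccc12` gives 15 nM, and compound 3 `Cc1cccc(C(=O)Nc2c(C(O)(C(F)(F)F)C(F)(F)F)ccc3ccccc23)c1` gives 23 nM; the step of a 1.5-fold higher number from compound 1 to compound 3 (0.19 log units; within the scatter) stays within the scatter. Compound 2 `O=C(Nc1ccc(Cl)cc1)Nc1c(C(O)(C(F)(F)F)C(F)(F)F)ccc2ccccc12` gives 276 nM, the highest number of the three: its nearest neighbour is compound 3, reached by a 12-fold lower number from compound 2 to compound 3 (1.08 log units; beyond the scatter), and its furthest is compound 1, reached by an 18-fold higher number from compound 1 to compound 2 (1.26 log units; beyond the scatter).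

The step under consideration leads from compound 2 to compound 4 `O=C(Nc1c(C(O)(C(F)(F)F)C(F)(F)F)ccc2ccccc12)c1cc(Cl)cc(Cl)c1`. The change is 3,5-dichlorophenyl in place of (4-chlorophenyl)amino on a carbonyl carbon. The step that bears most directly on it is a 12-fold lower number from compound 2 to compound 3 (1.08 log units; beyond the scatter), where an aromatic ring likewise took the place of (4-chlorophenyl)amino on the carbonyl carbon and the number fell well beyond the scatter. The step of an 18-fold higher number from compound 1 to compound 2 (1.26 log units; beyond the scatter) shows the same pattern from the other side: the compound carrying (4-chlorophenyl)amino on the carbonyl carbon stands far above the two carbon-linked analogues. Going by the values given here, no measured step separates 3,5-dichlorophenyl from 3-methylphenyl, so that part of the change is unsupported. Compound 4 is therefore expected to give 30 nM, within a range from 8 nM to 120 nM. The expected step is a 9.2-fold lower number from compound 2 to compound 4 (0.96 log units; beyond the scatter), a fall beyond the scatter.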

Compound 4, half-maximal effective concentration: 306 nM
The estimate for compound 4 lay 10-fold (1.01 log units) below the measured number; the measured number lies above the stated range.
By their numbers in this assay, from the lowest: compounds 1 and 3 (each within the scatter of the next); then compounds 2 and 4 (each within the scatter of the next).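

Compound 4 shows that removing the amino nitrogen from this position does not by itself lower the number in this assay: with 3,5-dichlorophenyl in place of (4-chlorophenyl)amino on the carbonyl carbon, the result stays level (a 1.1-fold higher number from compound 2 to compound 4 (0.04 log units; within the scatter)). A carbon-linked group on this carbonyl is therefore no guarantee of a low number, and compound 4 goes against the pattern that compounds 1, 2 and 3 had suggested. The position also proves sensitive to the identity of the carbon-linked group, as the number rises both on going from 3-methylphenyl to 3,5-dichlorophenyl (a 13-fold higher number from compound 3 to compound 4 (1.12 log units; beyond the scatter)) and on going from ethyl to 3,5-dichlorophenyl (a 20-fold higher number from compound 1 to compound 4 (1.31 log units; beyond the scatter)), and no measurement at hand explains these differences.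

The compounds shown leave open whether the rise from compound 3 follows from chlorine itself or from the ring carrying two groups, a question that an unsubstituted phenyl ring, a ring with a single chlorine or a ring with two methyl groups would help to settle. They also leave open how 3,5-dichlorophenyl would behave when attached through an amino nitrogen, since compounds 2 and 4 differ in both the link and the chlorine pattern.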